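The compounds below may be only part of what the source reports. "The series", "measured", "known", "first", "only" and "open" are said of these compounds alone.

Compound 3 `ClCc1ccc(Cn2cnc3c(Cl)nc(Cl)nc32)cc1` and compound 2 `ClCc1cccc(Cn2cnc3c(Cl)nc(Cl)nc32)c1` are built from the same atoms joined differently; the difference between the two cores is not broken down here. In a functional assay on NCI-H322M cells (Homo sapiens) for cytotoxicity, read by sulforhodamine B assay, with a stated time of 48 h (a higher number here means that more compound is tolerated, a lower number that less compound is tolerated), compound 3 gives 50100 nM, and compound 2 gives 15900 nM, the lowest of the three measured numbers. Compound 1 `Nc1nc(Cl)c2ncn(Cc3ccc(CCl)cc3)c2n1` comes from compound 3 by a single change, (amino in place of chloro on an aromatic carbon). In this assay compound 1 gives 87100 nM, so the step is a 1.7-fold higher number from compound 3 to compound 1 (0.24 log units; within the scatter). Compound 4 `Nc1nc(Cl)c2ncn(Cc3cccc(CCl)c3)c2n1` has not been measured in this assay; it comes from compound 2 by the same change, (amino in place of chloro on an aromatic carbon). The surroundings of the changed carbon are described in the same words in both cases, so this is the same change, and among the measured compounds it has been seen only once. Because the earlier step was a 1.7-fold higher number from compound 3 to compound 1 (0.24 log units; within the scatter), the expected step is a 1.7-fold higher number from compound 2 to compound 4 (0.23 log units; within the scatter), which would leave compound 4 near compound 2. Compound 4 is therefore estimated at 27000 nM, with an expected range from 12000 nM to 60000 nM.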

Compound 4, concentration lethal to 50% of the cells: 46800 nM
Compound 4: the middle estimate sits 1.7-fold (0.24 log units) below what was measured, and the stated range covers the measured number.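

In this assay, putting amino in place of chloro on the aromatic carbon gives a 2.9-fold higher number from compound 2 to compound 4 (0.47 log units; beyond the scatter), so on this core more compound is tolerated after the change. Set beside the earlier case, the two steps agree as closely as repeated measurements of this kind would be expected to: the same change on two cores in this assay, a 1.7-fold higher number (0.24 log units; within the scatter) from compound 3 to compound 1 and a 2.9-fold higher number (0.47 log units; beyond the scatter) from compound 2 to compound 4, 1.7-fold (0.23 log units) apart, within the scatter of two such steps. Going by these compounds alone, this suggests that the change carries over between these two cores with a similar size of step, but it rests on only two pairs, only the newer step lies beyond the scatter, and it says neither why the number moves nor whether the same would hold on a third core.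

The compounds shown leave open whether another group in that place, such as methylamino or hydroxyl, would behave as amino does. They also leave open what happens on either core if the chloromethyl group gives way to a plain methyl or a hydroxymethyl group.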